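The source may report more compounds than this note shows. Statements on the series, on what has been measured and on what is new or still open speak of the compounds shown alone.

Measured so far in an ADME assay on MT2 cells (Homo sapiens) for cytotoxicity, read by XTT assay, with a stated time of 4 days; on this read-out higher numbers stand for lower toxicity in this test and lower numbers for higher toxicity in this test:
compound 1 `CCOC(=O)/C(C#N)=C/c1cc(C)n(-c2cccc(-c3nnn[nH]3)c2)c1C` gives 76800 nM
compound 2 `Cc1cc(/C=C2\SC(=S)N(c3cccc(O)c3)C2=O)c(C)n1-c1cccc(-c2nnn[nH]2)c1` gives 35600 nM
compound 3 `Cc1cc(/C=C2\SC(=S)N(c3cccc(Br)c3)C2=O)c(C)n1-c1cccc(-c2nnn[nH]2)c1` gives 22600 nM

Compound 3 has the lowest of the three numbers in this assay; compound 2 is nearest and lies within the scatter of it, while compound 1 stands furthest, beyond the scatter. Compound 4 `Cc1cc(/C=C2\SC(=S)N(Cc3ccccc3)C2=O)c(C)n1-c1cccc(-c2nnn[nH]2)c1` differs from compound 3 by benzyl in place of 3-bromophenyl on an amide-type nitrogen in a ring. For the measured compounds named here, no measured step replaces the whole group on this ring nitrogen; the only step touching that group, a 1.6-fold lower number from compound 2 to compound 3 (0.20 log units; within the scatter), swapped one substituent on the phenyl and stayed within the scatter. On that basis the expected step of a 1.1-fold higher number from compound 3 to compound 4 (0.04 log units; within the scatter) is none beyond the scatter. For compound 4 the estimate in this assay is 25000 nM, with a range from 10000 nM to 60000 nM.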

Compound 4, half-maximal cytotoxic concentration: 150000 nM
Beside the measured number, compound 4's estimate is 6.0-fold (0.78 log units) below it, outside the stated range (above it).
By their numbers in this assay, from the lowest: compounds 3 and 2 (each within the scatter of the next); then compounds 1 and 4 (each within the scatter of the next).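

In this assay the group on this amide-type ring nitrogen proves to count: benzyl brings a 6.6-fold higher number from compound 3 to compound 4 (0.82 log units; beyond the scatter) and also a 4.2-fold higher number from compound 2 to compound 4 (0.62 log units; beyond the scatter) with both steps beyond the scatter. For the compounds shown here, the earlier swap of one substituent on the phenyl stayed within the scatter, so replacing the whole group is the first change here to move the number clearly, towards lower toxicity in this test. No evidence is available to explain this shift. The compounds shown leave open whether a plain phenyl or a phenethyl group on this nitrogen would fall with compound 4 or with compound 3. They also leave open whether a bromo group on the benzyl ring would bring the number back down.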